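Three Fluorines in Place of One on the Phenyl Group

A few compounds are considered here, and "the series" means these few. Any claim that something is new, unique, unknown or untested is made for them only; others in the source may bear on it.

Three measured compounds share one core and differ only in the aromatic group on a ring nitrogen. Compound 1 `CC(C)=CCC/C(C)=C/CC/C(C)=C/CC[C@@H]1[C@@]2(C)CC/C(=N\OCc3cn(-c4ccccc4)nn3)C(C)(C)[C@@H]2CC[C@@]1(C)O` gives 8830 nM in a functional assay on DU-145 cells (Homo sapiens) for cytotoxicity, read by MTT assay, with a stated time of 48 h; on this read-out lower numbers stand for stronger inhibition and higher numbers for weaker inhibition. Compound 2 `CC(C)=CCC/C(C)=C/CC/C(C)=C/CC[C@@H]1[C@@]2(C)CC/C(=N\OCc3cn(-c4ccc(F)cc4)nn3)C(C)(C)[C@@H]2CC[C@@]1(C)O` gives 21600 nM in this assay, and compound 3 `CC(C)=CCC/C(C)=C/CC/C(C)=C/CC[C@@H]1[C@@]2(C)CC/C(=N\OCc3cn(-c4ccccc4C#N)nn3)C(C)(C)[C@@H]2CC[C@@]1(C)O` gives 25100 nM. Among these three numbers compound 2 stands second highest: the step of a 1.2-fold higher number from compound 2 to compound 3 (0.07 log units; within the scatter) lies within the scatter, whereas the step of a 2.4-fold higher number from compound 1 to compound 2 (0.39 log units; beyond the scatter) lies beyond it.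

Compound 4 `CC(C)=CCC/C(C)=C/CC/C(C)=C/CC[C@@H]1[C@@]2(C)CC/C(=N\OCc3cn(-c4ccc(F)c(F)c4F)nn3)C(C)(C)[C@@H]2CC[C@@]1(C)O` has not yet been measured. The change 2,3,4-trifluorophenyl in place of 4-fluorophenyl on an aromatic nitrogen brings more fluorine onto the phenyl group. For the measured compounds named here, two measured steps bear on this: a 2.4-fold higher number from compound 1 to compound 2 (0.39 log units; beyond the scatter) and a 2.8-fold higher number from compound 1 to compound 3 (0.45 log units; beyond the scatter), each a modest rise in the number when a substituent entered the phenyl group. On that basis the expected step is small, upward or none beyond the scatter, a 1.3-fold higher number from compound 2 to compound 4 (0.11 log units; within the scatter). Compound 4 is therefore estimated at 28000 nM, with a range from 12000 nM to 65000 nM.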

Compound 4, half-maximal inhibitory concentration: 30400 nM
Compound 4: middle estimate off by 1.1-fold (0.04 log units), on the low side, within the range that was stated.
By their numbers in this assay, from the lowest: compound 1; then compounds 2, 3 and 4 (each within the scatter of the next).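

In this assay the step of a 1.4-fold higher number from compound 2 to compound 4 (0.15 log units; within the scatter) stays within the scatter, so the extra fluorines on the phenyl group do not separate compound 4 from the single-fluorine compound, and the step of a 1.2-fold higher number from compound 3 to compound 4 (0.08 log units; within the scatter) shows that 2,3,4-trifluorophenyl and 2-cyanophenyl cannot be told apart here either. The step of a 3.4-fold higher number from compound 1 to compound 4 (0.54 log units; beyond the scatter) lies beyond the scatter, which makes compound 4 the third substituted compound whose number sits clearly higher than that of plain phenyl, with none of the four going against this. No measurement is available that explains this pattern.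

Still open, from the compounds shown here alone, is whether any substituent on the phenyl group, such as a methoxy group, an amine or a carboxylic acid, could bring the number down instead of up. Also open, going by these compounds, is whether the ring nitrogen needs an aromatic group at all, which a benzyl group or a butyl chain in that place would test.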